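A few compounds are considered here, and "the series" means these few. Any claim that something is new, unique, unknown or untested is made for them only; others in the source may bear on it.

Measured compounds:
- compound 1, `CC(=O)Nc1ccc2oc(-c3ccc(F)cc3)cc(=O)c2c1`: 203000 nM
- compound 2, `CC(=O)Nc1ccc2oc(-c3ccc(C(F)(F)F)cc3)cc(=O)c2c1`: 330000 nM
- compound 3, `COc1c(-c2ccc(F)cc2)oc2ccc(NC(C)=O)cc2c1=O`: 317000 nM

All three were measured in an ADME assay on MT4 cells (Homo sapiens) for cytotoxicity, read by MTT assay, with a stated time of 4 days; a higher number here means that more compound is tolerated, a lower number that less compound is tolerated. Compound 2 and compound 3 differ from compound 1 by one change each. From compound 1 to compound 2 the change is trifluoromethyl in place of fluoro on an aromatic carbon, and the step is a 1.6-fold higher number from compound 1 to compound 2 (0.21 log units; within the scatter). From compound 1 to compound 3 the change is methoxy in place of hydrogen on an aromatic carbon, and the step is a 1.6-fold higher number from compound 1 to compound 3 (0.19 log units; within the scatter). Compound 2 and compound 3 show values that lie close together.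

Compound 4, `COc1c(-c2ccc(C(F)(F)F)cc2)oc2ccc(NC(C)=O)cc2c1=O`, is not yet measured in this assay. It differs from compound 3 by trifluoromethyl in place of fluoro on an aromatic carbon, the same change as that from compound 1 to compound 2, made here on the core of compound 3, which carries a methoxy where compound 1 carries hydrogen. Going by the values given here, for compound 4 the expected step is a 1.4-fold higher number from compound 3 to compound 4 (0.15 log units; within the scatter), resting on the single earlier step of a 1.6-fold higher number from compound 1 to compound 2 (0.21 log units; within the scatter) made on the core of compound 1. The estimate for compound 4 in this assay is 450000 nM.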

Compound 4, half-maximal cytotoxic concentration: 332000 nM
The estimate for compound 4 lay 1.4-fold (0.13 log units) above the measured number; low and high end bracket the measured number.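

In this assay, trifluoromethyl in place of fluoro gives a 1.0-fold higher number from compound 3 to compound 4 (0.02 log units; within the scatter), and this agrees with the earlier step on the core of compound 1: the same change on two cores in this assay, a 1.6-fold higher number (0.21 log units; within the scatter) from compound 1 to compound 2 and a 1.0-fold higher number (0.02 log units; within the scatter) from compound 3 to compound 4, 1.6-fold (0.19 log units) apart, within the scatter of two such steps
Methoxy in place of hydrogen gives a 1.0-fold higher number from compound 2 to compound 4 (0.00 log units; within the scatter), and this likewise agrees with the earlier step: the same change on two cores in this assay, a 1.6-fold higher number (0.19 log units; within the scatter) from compound 1 to compound 3 and a 1.0-fold higher number (0.00 log units; within the scatter) from compound 2 to compound 4, 1.6-fold (0.19 log units) apart, within the scatter of two such steps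
Going by these compounds alone, neither change differs measurably between these two cores, but every step lies within the scatter, so the agreement shows only that neither change moved the number on either core, not that a larger step would carry over in the same way.

Still open, on these data alone, is whether an amine or a carboxylic acid in place of trifluoromethyl would give a step beyond the scatter. The same holds for a longer chain in place of methoxy.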